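Swapping Cyclohexyl for Oxan-4-yl on the Ring Nitrogen Chain

A few compounds are considered here, and "the series" means these few. Any claim that something is new, unique, unknown or untested is made for them only; others in the source may bear on it.

Measured so far:
compound 1, `CNC(=O)c1cc(C(=O)NCCC2CCOCC2)cn(Cc2ccccc2)c1=O`: >= 127 ug/mL
compound 2, `CNC(=O)c1cc(C(=O)NC2CC2)cn(CC2CCCCC2)c1=O`: >= 148 ug/mL

In a physicochemical assay for solubility (a higher number here means a more soluble compound, a lower number a less soluble compound), compound 2 reaches only a limit, >= 148 ug/mL, so no exact number is known for it. Compound 1 likewise sits at a limit in this assay, >= 127 ug/mL. Compound 3, `CNC(=O)c1cc(C(=O)NC2CC2)cn(CC2CCOCC2)c1=O`, differs from compound 2 by oxan-4-yl in place of cyclohexyl on a saturated chain carbon bound to an aromatic nitrogen. No measured step between compounds differing in one place is available, so the size of this change cannot be judged from the shown data. For compound 3 the step that the limit leaves unreadable from compound 2 to compound 3 is expected to be small and, if anything, upward. Compound 3 is estimated at 200 ug/mL, within 100 ug/mL to 500 ug/mL, with a good chance that this assay again reports only a limit.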

Compound 3, solubility: >= 165 ug/mL
Compound 3: only a limit was reported; the forecaster's own chance of this, stated with the estimate: 75%; the middle value is on the limit's open side.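

Compound 2 and compound 3 both sit at limits in this assay, so no step can be read between them. The compounds shown leave open whether oxan-4-yl in place of cyclohexyl changes this read-out at all, and by how much.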